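This account rests on a few compounds, and the source may have more. Where it says the series, first, only, none or still open, it means among the compounds named here.

Of the compounds shown here, two from this series have been tested in a functional assay on MCF7 cells (Homo sapiens) for cytotoxicity, read by MTT assay, with a stated time of 24 h, tested at 32 ug/mL; a lower number here means a weaker effect, a higher number a stronger effect of the compound at the concentration tested. Compound 1 `Cn1c(-c2ccc(NC(=O)CSc3nc4ccccc4o3)cc2)nc(-c2ccccc2)c1-c1ccccc1` gives 71.5%. Compound 2 `Cn1c(-c2ccc(NC(=O)CSC3=NCCS3)cc2)nc(-c2ccccc2)c1-c1ccccc1` gives 52.5%. Among the compounds with values here, the only step between them is a number 19 percentage points lower from compound 1 to compound 2 (beyond the scatter), so compound 2 stands lowest of the two numbers, with compound 1 the nearest and higher.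

Compound 3 `Cn1ccnc1SCC(=O)Nc1ccc(-c2nc(-c3ccccc3)c(-c3ccccc3)n2C)cc1` is not yet measured. Compared with compound 2 the change is a group of 6 heavy atoms (4 carbon, 2 nitrogen; one five-membered aromatic ring with 2 hetero atoms) in place of a group of 5 heavy atoms (3 carbon, 1 nitrogen, 1 sulfur; one five-membered non-aromatic ring with 2 hetero atoms), on a sulfur. Within the data shown here, only one measured step touches the same place: the step from compound 1 to compound 2, which also swapped the group on that sulfur and cost a modest drop. That step went from a larger aromatic group to a small non-aromatic ring; the new change goes back to an aromatic five-membered ring, though a smaller one than compound 1 carries. On that slender basis an increase of moderate size in this assay is expected for compound 3, as a number 7.5 percentage points higher from compound 2 to compound 3 (within the scatter), though the scatter leaves room for no real change. The estimate for compound 3 is 60%, within a range from 45% to 75%.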

Compound 3, a percentage reported as activity, at one concentration (the size of the read-out at that concentration, not a potency): 43.4%
Compound 3: the middle estimate sits 16.6 percentage points above what was measured; measured number outside the range, below it.
By their numbers in this assay, from the lowest: compounds 3 and 2 (each within the scatter of the next); then compound 1.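

In this assay, an aromatic five-membered ring on this sulfur does not bring back the number of compound 1: a number 9.1 percentage points lower from compound 2 to compound 3 (within the scatter), and this step stays within the scatter, so 1-methyl-1H-imidazol-2-yl and the non-aromatic ring cannot be told apart here. The wider comparison, a number 28.1 percentage points lower from compound 1 to compound 3 (beyond the scatter), lies beyond the scatter, which shows that among these three compounds only compound 1 stands apart, and its 1,3-benzoxazol-2-yl is the only one of the three groups that also carries a six-membered aromatic ring. No measurement shown here explains this difference.

The three compounds cannot separate the part played by that second ring from the part played by the other atoms of 1,3-benzoxazol-2-yl; a 1,3-benzothiazol-2-yl or a 1H-benzimidazol-2-yl group on the same sulfur would bear on that question. All three numbers also come from a single concentration, so they leave open how the compounds would compare across a range of concentrations.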